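Swapping a Propylcarbonyl for an Aryl Thiocarbonyl Group

A few compounds are considered here, and "the series" means these few. Any claim that something is new, unique, unknown or untested is made for them only; others in the source may bear on it.

Of the compounds shown here, three of one family have been tested in an ADME assay on Huh-7 cells (Homo sapiens) for cytotoxicity; a higher number here means that more compound is tolerated, a lower number that less compound is tolerated. Compound 1 `O=C(NC(=S)N1CCc2cc(OCc3ccccc3)ccc21)c1ccccc1` gives 45200 nM. Compound 2 `CN(C)c1ccc(C(=O)NC(=S)N2CCc3c(OCCCCCOc4ccc(Cl)cc4)cccc32)cc1` reaches only the limit of the assay, > 50000 nM, so no number is known for it. Compound 3 `CCCC(=O)NC(=S)N1CCc2c(OCCCCCOc3ccc(Cl)cc3)cccc21` likewise stops at a limit, > 50000 nM, and therefore stands at the edge of what this assay can report rather than at a measured value. The step that the two limits leave unreadable from compound 2 to compound 3 cannot be read in size, since both of its ends are limits; the two compounds share (the limit of > 50000 nM in this assay, at which 2 of the 3 values shown sit).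

Compound 4 `S=C(NC(=S)N1CCc2c(OCCCCCOc3ccc(Cl)cc3)cccc21)Oc1ccccc1` differs from compound 3 in one place: a group of 9 heavy atoms (7 carbon, 1 oxygen, 1 sulfur; one six-membered aromatic ring of carbon only) in place of a group of 5 heavy atoms (4 carbon, 1 oxygen; no ring), on an amide-type nitrogen. Among the measured steps, only the one from compound 2 to compound 3 changes the same region of the molecule, and its size is not readable. Compound 1, the only one of the three with a measured number, gives 45200 nM. Nothing in the measured compounds points to a drop in tolerated concentration for this kind of change, so compound 4 is expected to remain at or near the limit, a step of a number no higher from compound 3 to compound 4 (the limit leaves the size open) with no change beyond the scatter. The estimated value for compound 4 in this assay is 50000 nM, within a range from 25000 nM to 100000 nM.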

Compound 4, half-maximal cytotoxic concentration: > 50000 nM
Compound 4 ended at the assay's limit; the forecaster's own chance of this, stated with the estimate: 65%; the middle value lies on the limit itself.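

In this assay compound 4 gives > 50000 nM, which is a limit and not a number. The steps to compound 4 from compound 2 and from compound 3 therefore cannot be read in size: the limit of > 50000 nM in this assay, at which 3 of the 4 values shown sit. From the compounds shown here alone, how far apart the tolerated concentrations of these three compounds truly lie stays open.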